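A few compounds are considered here, and "the series" means these few. Any claim that something is new, unique, unknown or untested is made for them only; others in the source may bear on it.

Values measured so far in a functional assay on SW-620 cells (Homo sapiens) for antiproliferative activity, read by MTT assay, with a stated time of 24 h; on this read-out higher numbers stand for weaker inhibition and lower numbers for stronger inhibition:
- Compound 1 `COc1ccc(C(=O)/C=C/c2ccc(Cl)cc2)c2c1C=CC(C)(C)O2`: > 10000 nM
- Compound 2 `COc1ccccc1/C=C/C(=O)c1ccc(OC)c2c1OC(C)(C)C=C2`: > 10000 nM

For compound 2, > 10000 nM is a limit and not a number. Going by the values given here, compound 1 offers no firmer reference point, as the series so far shows (the limit of > 10000 nM in this assay, at which 2 of the 2 values shown sit).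

Compound 3 `COc1ccc(C(=O)/C=C/c2ccc(O)cc2)c2c1C=CC(C)(C)O2` has not yet been measured. It keeps the shared core, but 4-hydroxyphenyl takes the place of 2-methoxyphenyl on a double-bonded chain carbon bound to a double-bonded chain carbon: 4-hydroxyphenyl in place of 2-methoxyphenyl on a double-bonded chain carbon bound to a double-bonded chain carbon.

Among the compounds with values here, only one measured step changes the group at this place: a step that the two limits leave unreadable from compound 1 to compound 2. Its size cannot be read, so it gives neither a size nor a direction to carry over. No clear shift beyond the usual scatter is therefore expected in this assay, and another limit would be no surprise. The expected step, only a rough estimate, is a step that the limit leaves unreadable from compound 2 to compound 3. For compound 3 the estimated value is 15000 nM, with an expected range from 5000 nM to 50000 nM.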

Compound 3, half-maximal inhibitory concentration: > 10000 nM
Compound 3 was reported as a limit; the forecaster's own chance of this, stated with the estimate: 65%; the middle value does not contradict the limit.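

Compound 3 gives > 10000 nM in this assay, which is a limit and not a number. No step among compound 1, compound 2 and compound 3 can be read, since all three sit at the same limit: the limit of > 10000 nM in this assay, at which 3 of the 3 values shown sit.

The compounds shown leave open whether changing the aromatic group on this chain shifts the inhibition at all, and in which direction.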